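The source may hold more compounds than are shown below. What is called first, only, known or untested is meant among the compounds shown, and "the series" means these compounds.

Compound 1, `COc1ccc(Cn2c(N)nc3c2c(=O)n(CC2CC2)c(=O)n3CC2CC2)cc1`: 60%
Compound 2, `Nc1nc2c(c(=O)n(CC3CC3)c(=O)n2CC2CC2)n1Cc1ccc([N+](=O)[O-])cc1`: 30%

Both were tested in an assay on isolated protein with dual specificity calcium/calmodulin-dependent 3',5'-cyclic nucleotide phosphodiesterase 1B (Bos taurus) as the target, tested at 100 uM; a lower number here means less inhibition, a higher number more inhibition at the concentration tested (going by the name of the read-out). Among these two numbers compound 2 stands lowest. Its nearest neighbour is compound 1, which gives 60% in this assay. The step between them is a number 30 percentage points lower from compound 1 to compound 2 (beyond the scatter), and it lies beyond the scatter; the two structures differ only by nitro in place of methoxy on an aromatic carbon.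

Compound 3, `Nc1nc2c(c(=O)n(CC3CC3)c(=O)n2CC2CC2)n1Cc1cccc2ccccc12`, has not yet been measured in this assay. It differs from compound 2 by naphthalen-1-yl in place of 4-nitrophenyl on a saturated chain carbon bound to an aromatic nitrogen. Among the compounds with values here, only one measured step bears on this change, a number 30 percentage points lower from compound 1 to compound 2 (beyond the scatter), and it is modest. Within the data shown here, compound 3 removes the nitro group that compound 2 carries, and the one step on record places the nitro-bearing compound 2 below compound 1, so a rise looks more likely than a further fall. The naphthalen-1-yl group itself has no measured comparison, so the size remains uncertain. The estimated step is a number 20 percentage points higher from compound 2 to compound 3 (beyond the scatter). Compound 3 is expected to show about 50% in this assay, with a range from 25% to 75%.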

Compound 3, a percentage reported as inhibition, at one concentration (the size of the read-out at that concentration, not a potency): 0%
For compound 3 the middle estimate is 50 percentage points above the measured one, outside the stated range (below it).
By their numbers in this assay, from the lowest: compound 3; then compound 2; then compound 1.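

At the saturated chain carbon bound to an aromatic nitrogen, replacing 4-nitrophenyl with naphthalen-1-yl gives a number 30 percentage points lower from compound 2 to compound 3 (beyond the scatter) in this assay, so removing the nitro group does not by itself restore inhibition. Replacing 4-methoxyphenyl with naphthalen-1-yl gives a number 60 percentage points lower from compound 1 to compound 3 (beyond the scatter), which makes this the largest change seen at this place and shows that the position responds to more than the choice between methoxy and nitro on a single ring. No measurement here explains why inhibition falls with naphthalen-1-yl.

Going by these compounds, it remains open how an unsubstituted phenyl group or a naphthalen-2-yl group would read at this place, and those two comparisons could help separate the effect of adding a second aromatic ring from that of the way the group is attached. A 4-chlorophenyl or 4-aminophenyl group would also test whether the order of compound 1 above compound 2 extends to other substituents, and each of these readings would still describe inhibition at a single concentration rather than potency.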